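The source may hold more compounds than are shown below. What is called first, only, known or untested is meant among the compounds shown, and "the series" means these compounds.

Among the measured compounds shown here, in a functional assay on A549 cells (Homo sapiens) for inhibition, read by MTT assay, with a stated time of 72 h (on this read-out lower numbers stand for stronger inhibition and higher numbers for weaker inhibition), three compounds have numbers so far. Compound 1 (`C/C=C\C(=O)Nc1cc(Nc2nc3c(c(-c4cn(C)c5ccccc45)n2)CSCC3)c(OC)cc1N(C)CCN(C)C`) gives 6860 nM, compound 2 (`CCC/C=C\C(=O)Nc1cc(Nc2nc3c(c(-c4cn(C)c5ccccc45)n2)CSCC3)c(OC)cc1N(C)CCN(C)C`) gives 571 nM, and compound 3 (`COc1cc(N(C)CCN(C)C)c(NC(=O)C=C(C)C)cc1Nc1nc2c(c(-c3cn(C)c4ccccc34)n1)CS(=O)(=O)CC2`) gives 787 nM. Compound 3 thus lies within the scatter of compound 2 and well below compound 1.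

Compound 4 (`CCC/C=C\C(=O)Nc1cc(Nc2nc3c(c(-c4cn(C)c5ccccc45)n2)CS(=O)(=O)CC3)c(OC)cc1N(C)CCN(C)C`) keeps the core of compound 3 and alters one group: pent-1-en-1-yl in place of 2-methylprop-1-en-1-yl on a carbonyl carbon. Pent-1-en-1-yl takes the place of 2-methylprop-1-en-1-yl on a carbonyl carbon.

For the measured compounds named here, one measured step bears on this change: a 12-fold lower number from compound 1 to compound 2 (1.08 log units; beyond the scatter). That large step put ethyl in place of hydrogen on a saturated chain carbon, but it is only a partial guide. It was measured on the core of compound 1, not that of compound 3, and it does not compare the two groups exchanged here. A closer hint is that pent-1-en-1-yl already stands on the core of compound 1, and with it compound 2 reads 571 nM, within the scatter of compound 3. No step beyond the scatter is therefore expected in this assay, in either direction.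

The expected change is a 1.3-fold lower number from compound 3 to compound 4 (0.10 log units; within the scatter). For compound 4 the estimate is 620 nM, with an expected range from 220 nM to 1700 nM.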

Compound 4, half-maximal inhibitory concentration: 57 nM
Estimate against measurement, compound 4: 11-fold (1.04 log units) above; the whole stated range lies above it.
By their numbers in this assay, from the lowest: compound 4; then compounds 2 and 3 (each within the scatter of the next); then compound 1.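

In this assay, the group on the carbonyl carbon of the amide matters strongly on the core of compound 3: a 14-fold lower number from compound 3 to compound 4 (1.14 log units; beyond the scatter) comes from exchanging 2-methylprop-1-en-1-yl for pent-1-en-1-yl, a change from 4 carbon to 5 carbon with no change in the hydrogen-bond counts. Together with a 12-fold lower number from compound 1 to compound 2 (1.08 log units; beyond the scatter), this gives a large step on each of the two cores when the group at this carbonyl carbon changes, and no compound shown goes against that, although the two steps start from different groups. Nothing measured here explains why the exchange has so large an effect on this read-out.

The compounds shown leave open whether the step follows from the added carbon or from the different shape of the chain, a question that a longer chain such as hex-1-en-1-yl and other chains of 5 carbon could help to settle. They also leave open how an amine, such as a dimethylamino group carried on this chain, would read in this assay.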